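Replacing a ring amine with an open-chain one

A few compounds are considered here, and "the series" means these few. Any claim that something is new, unique, unknown or untested is made for them only; others in the source may bear on it.

The shared core of compound 1 `O=c1cc(CSC(=S)N2CCCC2)oc2ccccc12` is tested in a functional assay on LM7 cells (Homo sapiens) for antiproliferative activity, read by MTT assay, with a stated time of 72 h (on this read-out higher numbers stand for weaker inhibition and lower numbers for stronger inhibition), where compound 1 gives 40000 nM. Compound 2 `O=c1cc(CSC(=S)N2CCCCC2)oc2ccccc12` carries piperidin-1-yl in place of pyrrolidin-1-yl; in this assay compound 2 reaches only a limit, reported as > 25000 nM. Compound 3 `O=c1cc(CSC(=S)N2CCCC2)oc2cc(Cl)ccc12` carries chloro in place of hydrogen on an aromatic carbon, and in this assay compound 3 likewise reaches only a limit, > 25000 nM. The step that the limit leaves unreadable from compound 1 to compound 2 and the step that the limit leaves unreadable from compound 1 to compound 3 therefore cannot be sized, because the limit of > 25000 nM in this assay, at which 2 of the 3 values shown sit, hides where two of the three compounds truly stand.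

Compound 4 `CCN(CC)C(=S)SCc1cc(=O)c2ccc(Cl)cc2o1` differs from compound 3 by diethylamino in place of pyrrolidin-1-yl on a thiocarbonyl carbon. No measured step exchanges a ring amine for an open-chain amine, so nothing shown speaks directly to this change, and compound 3 itself offers only a limit as a starting point. Among the measured compounds shown here, the only guide is that compound 1 gives 40000 nM in this assay and that all three compounds sit at or near the weak end.

The step that the limit leaves unreadable from compound 3 to compound 4 is therefore expected to stay unreadable, with compound 4 most likely reported again as a limit. On that basis compound 4 is estimated at 35000 nM, within a range from 10000 nM to 120000 nM.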

Compound 4, half-maximal inhibitory concentration: 8800 nM
Compound 4: middle estimate off by 4.0-fold (0.60 log units), on the high side; measured number below the stated range.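

In this assay, among the compounds shown here, diethylamino in place of pyrrolidin-1-yl on a thiocarbonyl carbon gives an at least 2.8-fold lower number from compound 3 to compound 4 (0.45 log units; beyond the scatter), the first step that can be read and the first to show that the amine on this carbon can shift the read-out beyond the usual scatter. Both groups count the same heavy atoms, 4 carbon and 1 nitrogen, so this change swaps a five-membered ring for an open-chain amine of the same atom count, and here the open-chain form gives the lower number and so the stronger inhibition. The step remains a minimum, with its full size unknown, because compound 3 offers only a limit as its starting point: the limit of > 25000 nM in this assay, at which 2 of the 4 values shown sit.

The compounds shown leave open whether diethylamino would bring a similar step on the core of compound 1, which carries hydrogen in place of the chloro group, since the other steps here cannot be read. They also leave open how other amines on this carbon would behave, such as dimethylamino, a longer open chain like dipropylamino, or a ring with a second hetero atom like morpholin-4-yl.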